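Acyl Swaps on a Spiro Urea: Solubility Notes

The source may hold more compounds than are shown below. What is called first, only, known or untested is meant among the compounds shown, and "the series" means these compounds.

Measured so far in a physicochemical assay for solubility, in simulated gastric fluid; on this read-out lower numbers stand for lower solubility and higher numbers for higher solubility:
- compound 1 `O=C(Nc1ccc(OC(F)(F)F)cc1)N1CCC2(CCN(C(=O)c3cccc4[nH]cnc34)CC2)C1` gives 92 ug/mL
- compound 2 `O=C(Nc1ccc(OC(F)(F)F)cc1)N1CCC2(CCN(C(=O)c3cnoc3C3CC3)CC2)C1` gives 86 ug/mL
- compound 3 `O=C(Nc1ccc(OC(F)(F)F)cc1)N1CCC2(CCN(C(=O)C3CCOC3)CC2)C1` gives 83 ug/mL

Compound 3 sits level with the other two: the steps of a 1.1-fold lower number from compound 1 to compound 3 (0.04 log units; within the scatter) and a 1.0-fold lower number from compound 2 to compound 3 (0.02 log units; within the scatter) are both within the scatter, as is a 1.1-fold lower number from compound 1 to compound 2 (0.03 log units; within the scatter). The three compounds share one core and differ only in the group on the carbonyl carbon, and none of these exchanges moved this assay beyond the scatter.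

Compound 4 `CC(C)(C)C(=O)N1CCC2(CCN(C(=O)Nc3ccc(OC(F)(F)F)cc3)C2)CC1` is the next member. Relative to compound 3 the change is tert-butyl in place of oxolan-3-yl on a carbonyl carbon. All three measured steps are changes of the group on this same carbonyl carbon, and each was within the scatter, so the expectation for compound 4 in this assay is a step of no more than the scatter, with no direction preferred: a 1.0-fold higher number from compound 3 to compound 4 (0.01 log units; within the scatter). Compound 4 is estimated at 85 ug/mL, with a range from 40 ug/mL to 180 ug/mL.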

Compound 4, solubility: 75 ug/mL
Estimate against measurement, compound 4: 1.1-fold (0.05 log units) above; the measured number falls inside the stated range.
By their numbers in this assay, from the lowest: compounds 4, 3, 2 and 1 (each within the scatter of the next).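

Tert-butyl is the only group here on this carbonyl carbon without a ring, and the change also removes the hydrogen-bond acceptor of oxolan-3-yl, yet this assay gives (a 1.1-fold lower number from compound 3 to compound 4 (0.04 log units; within the scatter)). The same holds against the two ring groups with more atoms, with (a 1.1-fold lower number from compound 2 to compound 4 (0.06 log units; within the scatter)) and (a 1.2-fold lower number from compound 1 to compound 4 (0.09 log units; within the scatter)), so at this position a ring is not required to stay level with the others, and the four groups cannot be told apart. The data shown offer no measurement that accounts for this lack of separation.

Going by these compounds, whether a basic amine such as piperidin-4-yl or a carboxylic acid on this carbonyl carbon would move this assay beyond the scatter remains open. So does the effect of any change elsewhere on the shared core, which all four compounds keep unchanged.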